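The compounds below may be only part of what the source reports. "The series", "measured", "known", "first", "only" and "open" are said of these compounds alone.

For the measured compounds named here, compound 1 `COc1ccc(S(=O)(=O)N2CCc3cccc(-c4ccc(N(C)C)cc4)c32)cc1` is the stronger of the two compounds measured so far in a functional assay on KB-VIN10 cells (Homo sapiens) for inhibition, with a stated time of 72 h; a higher number here means a weaker inhibitor, a lower number a stronger inhibitor: in this assay compound 1 gives 553 nM, the lower of the two numbers. Compound 2 `COc1ccc(S(=O)(=O)N2CCc3cccc(-c4c(F)c(F)c(F)c(F)c4F)c32)cc1` shares the same core and differs only in the group on the same aromatic carbon, and in this assay compound 2 gives 4630 nM, a gap from compound 1 that lies beyond the usual scatter. Going by the values given here, the two values together show that the group on that carbon matters for the half-maximal inhibitory concentration, though with only two compounds no rule can be drawn.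

Compound 3 `COc1ccc(S(=O)(=O)N2CCc3cccc(-c4cccs4)c32)cc1` is the next compound to be measured. It differs from compound 1 in one place: thiophen-2-yl in place of 4-(dimethylamino)phenyl on an aromatic carbon. Among the compounds with values here, no pair of measured compounds with a single change is at hand to calibrate this step, so the expectation rests on the two values alone. Compound 3 is expected to be somewhat weaker than compound 1, with an estimated step of a 2.2-fold higher number from compound 1 to compound 3 (0.34 log units; beyond the scatter) in this assay. The estimate for compound 3 in this assay is 1200 nM, with a range from 400 nM to 4000 nM.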

Compound 3, half-maximal inhibitory concentration: 251 nM
For compound 3 the middle estimate is 4.8-fold (0.68 log units) above the measured one; the whole stated range lies above it.
By their numbers in this assay, from the lowest: compound 3; then compound 1; then compound 2.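

Replacing 4-(dimethylamino)phenyl with thiophen-2-yl on this aromatic carbon, ortho to a fused ring and meta to a fused ring, gives a 2.2-fold lower number from compound 1 to compound 3 (0.34 log units; beyond the scatter) in this assay. This shows that a six-membered aromatic ring of carbon only is not required at this position: a five-membered aromatic ring with 1 hetero atom is accepted, and with 5 heavy atoms in place of 9, the smaller group, which has no nitrogen, still gives the lower number. The data record this change but offer no measurement that would account for it.

Whether the sulfur of thiophen-2-yl or the point of attachment on that ring matters remains open, as furan-2-yl, thiophen-3-yl and unsubstituted phenyl do not stand among the compounds shown. Also open, going by these compounds, is how a saturated amine such as morpholine or piperidine, or a carboxylic acid, would read at this aromatic carbon in this assay.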